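The compounds below may be only part of what the source reports. "The series", "measured", "known", "first", "only" and "open" are said of these compounds alone.

Measured so far:
compound 1 `COc1ccc(Nc2nc(/C=C/c3cc(OC)c(OC)c(OC)c3)nc3ccsc23)cc1` — 279000 nM
compound 2 `COc1cc(/C=C/c2nc(N(C)c3ccccc3)c3sccc3n2)cc(OC)c1OC` — 767000 nM

Two compounds have numbers in a functional assay on L02 cells (Homo sapiens) for inhibition, read by Griess assay, with stated times of 1 h and 24 h; on this read-out lower numbers stand for stronger inhibition and higher numbers for weaker inhibition. Among the compounds with values here, compound 2 stands highest of the two; its nearest neighbour is compound 1, and the only step measured, a 2.7-fold higher number from compound 1 to compound 2 (0.44 log units; beyond the scatter), separates them. Compound 3 `COc1cc(/C=C/c2nc(NCc3ccc(C)cc3)c3sccc3n2)cc(OC)c1OC` has not yet been measured. It differs from compound 2 in one place: (4-methylbenzyl)amino in place of methyl(phenyl)amino on an aromatic carbon. The new group brings one hydrogen-bond donor, which compound 2 lacks and compound 1 has. Within the data shown here, the only step that bears on this change is the one from compound 1 to compound 2, a modest rise when the donor-bearing group gave way to methyl(phenyl)amino. Undoing that group might undo part of that rise, but no measured pair tests a benzylamino group, so the expectation is weak. Compound 3 is therefore expected to give a number a little below compound 2, with the step of a 1.9-fold lower number from compound 2 to compound 3 (0.28 log units; within the scatter) expected to stay modest. Compound 3 is estimated at 400000 nM, within a range from 150000 nM to 900000 nM.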

Compound 3, half-maximal inhibitory concentration: > 1000000 nM
Compound 3 was reported as a limit; the forecaster's own chance of this, stated with the estimate: 15%; at least 2.5-fold (0.39 log units) between middle value and limit.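

In this assay, compound 3 is reported only as a limit: the limit of > 1000000 nM in this assay, at which 1 of the 3 values shown sits.

Placing (4-methylbenzyl)amino on this aromatic carbon gives an at least 1.3-fold higher number from compound 2 to compound 3 (0.11 log units; that floor lies within the scatter), so a hydrogen-bond donor in the group at this position did not by itself bring the number back towards that of compound 1. The comparison with compound 1 is the first among these compounds in which the nitrogen keeps its hydrogen while its substituent changes, and 4-methylbenzyl in place of 4-methoxyphenyl gives an at least 3.5-fold higher number from compound 1 to compound 3 (0.55 log units; beyond the scatter). The donor alone therefore does not set the number here: the group carried on that nitrogen also matters, and among the three compounds only compound 1, with its 4-methoxyphenyl, has a number clearly below the others.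

The compounds shown do not separate the effect of the methoxy group from that of the extra carbon in the benzyl link, a question that a 4-methoxybenzyl or an unsubstituted phenyl on the same nitrogen would address. They also leave open how a saturated amine such as morpholine or a small alkylamino group would behave on this aromatic carbon.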